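The source may report more compounds than this note shows. Statements on the series, on what has been measured and on what is new or still open speak of the compounds shown alone.

Series built on the core of compound 1 `O=C(CSc1nc(Nc2ccccc2)c2ccccc2n1)Nc1ccc(F)cc1` with the amide-type nitrogen carrying a substituted phenyl. In a functional assay on MGC-803 cells (Homo sapiens) for inhibition, read by MTT assay, with a stated time of 72 h (on this read-out lower numbers stand for stronger inhibition and higher numbers for weaker inhibition), compound 1 gives > 50000 nM, a limit of the assay and not a number. Compound 2 `O=C(CSc1nc(Nc2ccccc2)c2ccccc2n1)Nc1ccc([N+](=O)[O-])cc1` in this assay gives > 50000 nM, again a limit. Compound 3 `O=C(CSc1nc(Nc2ccccc2)c2ccccc2n1)Nc1ccc(C(F)(F)F)cc1` in this assay gives 8670 nM, the only number shown for the series, with two other values sitting at the limit of > 50000 nM in this assay, at which 2 of the 3 values shown sit. The steps of an at least 5.7-fold lower number from compound 1 to compound 3 (0.76 log units; beyond the scatter) and an at least 5.7-fold lower number from compound 2 to compound 3 (0.76 log units; beyond the scatter) are read only against that limit, while a step that the two limits leave unreadable from compound 1 to compound 2 stays unreadable.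

Compound 4 `O=C(CSc1nc(Nc2ccccc2)c2ccccc2n1)Nc1ccc(Cl)c(Cl)c1` differs from compound 3 by 3,4-dichlorophenyl in place of 4-(trifluoromethyl)phenyl on an amide-type nitrogen. For the measured compounds named here, no measured step exchanges one halogenated phenyl for another, so the change is expected to stay near the scatter, a 1.0-fold higher number from compound 3 to compound 4 (0.02 log units; within the scatter). Compound 4 in this assay is estimated at 9000 nM, between 3000 nM and 40000 nM.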

Compound 4, half-maximal inhibitory concentration: 37900 nM
Compound 4: the middle estimate sits 4.2-fold (0.62 log units) below what was measured; measured number inside the range.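

The series now holds a step at the amide-type nitrogen with a number at both ends: a 4.4-fold higher number from compound 3 to compound 4 (0.64 log units; beyond the scatter) shows that 3,4-dichlorophenyl does not match 4-(trifluoromethyl)phenyl at this position. The steps of an at least 1.3-fold lower number from compound 2 to compound 4 (0.12 log units; that floor lies within the scatter) and an at least 1.3-fold lower number from compound 1 to compound 4 (0.12 log units; that floor lies within the scatter) establish no separation from the 4-nitrophenyl and 4-fluorophenyl members, as each is read only against a limit: the limit of > 50000 nM in this assay, at which 2 of the 4 values shown sit.

Open, on these data alone, is whether 4-chlorophenyl would read closer to compound 3 or compound 4. Also open, as far as these compounds go, is how an amine or a carboxylic acid on this phenyl would read.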